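The source may report more compounds than this note shows. Statements on the series, on what has been measured and on what is new or still open speak of the compounds shown alone.

Compound 1 `Cc1cc(C)c(S(=O)(=O)N2CCC(N3CCN(C)CC3)CC2)c(C)c1` is the starting point. In an ADME assay on HCT-116 cells (Homo sapiens) for cytotoxicity, read by CellTiter-Glo, with a stated time of 72 h (on this read-out lower numbers stand for stronger inhibition and higher numbers for weaker inhibition), compound 1 gives > 5000 nM, and this is a limit of the assay rather than a measured number. A second compound, compound 2 `CC1CCN(C2CCN(S(=O)(=O)c3ccc(OC(F)(F)F)cc3)CC2)CC1`, is the only other one measured: in this assay compound 2 gives > 5000 nM, again a limit. So compound 1 stands at the same limit as everything else shown, and nothing places it higher or lower; this is summed up by the limit of > 5000 nM in this assay, at which 2 of the 2 values shown sit.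

Compound 3 `Cc1cc(C)c(S(=O)(=O)N2CCC(N3CCC(C)OC3)CC2)c(C)c1` has not yet been measured. It differs from compound 1 in one spot: a group of 7 heavy atoms (5 carbon, 1 nitrogen, 1 oxygen; one six-membered non-aromatic ring with 2 hetero atoms) in place of a group of 7 heavy atoms (5 carbon, 2 nitrogen; one six-membered non-aromatic ring with 2 hetero atoms), on a saturated ring carbon. Neither of the two measured compounds gives a step to compare with, so any expectation rests on the fact that both sit at the limit. The change from compound 1 to compound 3 is expected to give a step that the limit leaves unreadable from compound 1 to compound 3, that is, no shift beyond the scatter, because compound 1 itself shows only > 5000 nM. Compound 3 is therefore estimated at 9000 nM, within a range from 3500 nM to 40000 nM.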

Compound 3, half-maximal inhibitory concentration: > 5000 nM
Compound 3 gave a limit, no number (the forecaster's own chance of this, stated with the estimate: 80%); the middle value does not contradict the limit.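

No step can be read between compound 1 and compound 3, because both give only a limit in this assay: the limit of > 5000 nM in this assay, at which 3 of the 3 values shown sit.

The compounds shown leave open what replacing the 4-methylpiperazin-1-yl group does to this read-out, and whether any change to the shared core gives a true measured number rather than a limit.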